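Core ethyl trimmed to methyl in the difluoromethoxy series

The compounds below may be only part of what the source reports. "The series", "measured", "known", "first", "only" and "open" are said of these compounds alone.

Notes on the series. Three compounds of the shared core carry measurements in an assay on IMR-32 cells for displacement of a labelled ligand from corticotropin-releasing factor receptor 1 (Homo sapiens), read by scintillation counting, with a stated time of 2 h; a higher number here means a weaker inhibitor, a lower number a stronger inhibitor. Compound 1 `CCc1nc(NC(CC)CC)c(OC)nc1-c1ccc(Cl)cc1Cl` gives 5.9 nM. Compound 2 `CCc1nc(NC(CC)CC)c(OC)nc1-c1ccc(OC(F)F)cc1Cl` gives 1.4 nM, and compound 3 `CCc1nc(-c2ccc(OC(F)(F)F)cc2OC)c(OC)nc1NC(CC)CC` gives 6.1 nM. Going by the values given here, the only single-point step among them is a 4.2-fold lower number from compound 1 to compound 2 (0.62 log units; beyond the scatter). On these numbers compound 2 stands lowest of the three; compound 1 sits a modest distance above it and compound 3 a little further, both gaps beyond the scatter.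

Compound 4 `CCC(CC)Nc1nc(C)c(-c2ccc(OC(F)F)cc2Cl)nc1OC` has not been measured in this assay. It differs from compound 2 at one place: hydrogen in place of methyl on a saturated chain carbon bound to an aromatic carbon Cut one bond further out, the same difference reads ethyl to methyl. Among the compounds with values here, no measured step touches this part of the core; the one recorded step concerns a substituent on the aromatic ring and gives no guide here. With nothing bearing on the change, a step no larger than the scatter is the working expectation, in either direction, and the range is kept wide. Compound 4 is therefore estimated at 2.5 nM, with a range of 0.8 nM to 8 nM. The step this estimate implies, a 1.8-fold higher number from compound 2 to compound 4 (0.25 log units; within the scatter), is expected to stay within the scatter.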

Compound 4, inhibition constant: 4.6 nM
For compound 4 the middle estimate is 1.8-fold (0.26 log units) below the measured one; the measured number falls inside the stated range.
By their numbers in this assay, from the lowest: compound 2; then compounds 4, 1 and 3 (each within the scatter of the next).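

In this assay, going by these compounds alone, ethyl to methyl on the shared core gives a weaker inhibitor (a 3.3-fold higher number from compound 2 to compound 4 (0.52 log units; beyond the scatter)), the first reading at this position, so removing this single carbon does not leave the number unchanged. The earlier step concerned a substituent on the aromatic ring, whereas this one shows that the saturated chain on the core also moves the number beyond the scatter, with ethyl the better of the two groups in the difluoromethoxy series. Nothing available bears on why this chain change moves the number.

Among the compounds shown, this position carries only ethyl and methyl, so it remains open whether a longer chain such as propyl, a cyclopropyl ring, or a methoxymethyl group would bring the number down further or raise it again. Going by these compounds, it also remains open whether the same trim from ethyl to methyl would give a step of similar size with the dichloro pattern of compound 1 or the trifluoromethoxy and methoxy pattern of compound 3.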